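Trimming Cyclopropyl to Methyl on the Oxazole Ring

This account rests on a few compounds, and the source may have more. Where it says the series, first, only, none or still open, it means among the compounds named here.

Compound 1 `CCOCc1cc(CCCOc2c(C)cc(-c3noc(C(F)(F)F)n3)cc2C)on1`: > 2.5 h
Compound 2 `Cc1cc(-c2noc(C3CC3)n2)cc(C)c1OCCCc1cc(C2CC2)no1`: > 2.5 h

In an in vitro ADME assay on microsomes from liver (Simiiformes) (on this read-out higher numbers stand for a longer-lived compound and lower numbers for a shorter-lived compound), compound 1 reaches > 2.5 h, which is a limit of the assay rather than a number. Compound 2 likewise gives > 2.5 h, again a limit. Both readings sit at the limit of > 2.5 h in this assay, at which 2 of the 2 values shown sit. Compound 3 `Cc1cc(CCCOc2c(C)cc(-c3noc(C4CC4)n3)cc2C)on1` differs from compound 2 in one place: methyl in place of cyclopropyl on an aromatic carbon. Going by the values given here, no measured step covers this change, so the step of a number no higher from compound 2 to compound 3 (the limit leaves the size open) is expected to be none beyond the scatter. Compound 3 is therefore expected to reach 2.5 h, within 1.5 h to 5 h, most likely again reported only as a limit.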

Compound 3, half-life: 2.23 h
Compound 3: the middle estimate sits 1.1-fold (0.05 log units) above what was measured; the range from low to high includes it.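

In this assay, going by these compounds alone, compound 3 is the first compound here to give a measured number rather than a limit, so with methyl at this position the read-out can actually be placed. Swapping cyclopropyl for methyl gives an at least 1.1-fold lower number from compound 2 to compound 3 (0.04 log units; that floor lies within the scatter) and so shows no change beyond the scatter so far. Only a floor can be stated, because compound 2 carries no exact number: the limit of > 2.5 h in this assay, at which 2 of the 3 values shown sit.

As far as these compounds go, how far compound 2 truly lies from compound 3 stays open. So does what a hydrogen, an amine or a longer chain would do at this position.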